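A few compounds are considered here, and "the series" means these few. Any claim that something is new, unique, unknown or untested is made for them only; others in the source may bear on it.

In an ADME assay on THP-1 cells (Homo sapiens) for cytotoxicity, read by flow cytometry and propidium iodide staining, with a stated time of 72 h (on this read-out lower numbers stand for stronger inhibition and higher numbers for weaker inhibition), compound 2 (`Nc1ccc2oc(-c3ccccc3)c(O)c(=O)c2c1`) gives 27000 nM, within the scatter of compound 1 (`CC(=O)Nc1ccc2oc(-c3ccccc3)c(O)c(=O)c2c1`) at 36000 nM, while compound 3 (`COc1cccc(-c2oc3ccc(N)cc3c(=O)c2O)c1`) gives 2000 nM. Compound 4 (`COc1c(-c2ccccc2)oc2ccc(N)cc2c1=O`) differs from compound 2 in one place: methyl in place of hydrogen on an oxygen on an aromatic ring, hydroxy to methoxy. Among the measured compounds shown here, no measured step touches that oxygen. The step of a 1.3-fold lower number from compound 1 to compound 2 (0.12 log units; within the scatter) lies at a nitrogen and within the scatter. The large step of a 14-fold lower number from compound 2 to compound 3 (1.13 log units; beyond the scatter) adds a methoxy on an aromatic carbon, elsewhere, and gives no direction here. No change beyond the scatter is expected. Compound 4 is estimated at 20000 nM, with a range of 7000 nM to 60000 nM. The expected change is a 1.4-fold lower number from compound 2 to compound 4 (0.13 log units; within the scatter).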

Compound 4, half-maximal inhibitory concentration: 74000 nM
Compound 4: the middle estimate sits 3.7-fold (0.57 log units) below what was measured; the measured number lies above the stated range.
By their numbers in this assay, from the lowest: compound 3; then compounds 2 and 1 (each within the scatter of the next); then compound 4.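

Hydroxy to methoxy on this oxygen gives a 2.7-fold higher number from compound 2 to compound 4 (0.44 log units; beyond the scatter) in this assay, the first measured change at this position and a modest one. The hydrogen on this oxygen therefore matters to this read-out, whereas the exchange of acetyl for hydrogen on the nitrogen stayed within the scatter. Nothing available explains this step.

On these data alone, it remains open whether an ethoxy or an acetoxy at this place would move the number in the same direction. As far as these compounds go, it is also open whether methyl on this oxygen has the same effect when the methoxy of compound 3 is present.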